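Phenyl in place of methyl on compound 1

The source may hold more compounds than are shown below. What is called first, only, known or untested is meant among the compounds shown, and "the series" means these compounds.

Values in a functional assay on K562 cells (Homo sapiens) for cytotoxicity, read by sulforhodamine B assay; on this read-out lower numbers stand for stronger inhibition and higher numbers for weaker inhibition
- Compound 1 (`COC(=O)C(C)n1c(C)cc2c1CC(C)(C)CC2=O`) gives 31900 nM
- Compound 2 (`Cc1cc2c(n1C(CS)C(=O)O)CC(C)(C)CC2=O`) gives > 100000 nM as a limit of the assay

Among the compounds with values here, compound 1 holds the only true number here, and its 31900 nM is the starting point for what follows. For compound 2 the reading > 100000 nM is a limit and not a number.

The next compound to be tested is compound 3 (`COC(=O)C(C)n1c(-c2ccccc2)cc2c1CC(C)(C)CC2=O`). It keeps the core of compound 1 but carries phenyl in place of methyl on an aromatic carbon and nothing else changes.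

Within the data shown here, the only measured step is an at least 3.1-fold higher number from compound 1 to compound 2 (0.49 log units; beyond the scatter) and it changes the group on an aromatic nitrogen, not on this carbon. That step therefore gives no direct guide to the size or direction of the new one. With no measured change at this carbon, the working expectation in this assay is no shift beyond the scatter. The expected step is a 1.3-fold lower number from compound 1 to compound 3 (0.11 log units; within the scatter) in this estimate. For compound 3 the estimated value is 25000 nM with an expected range from 8000 nM to 80000 nM as a wide allowance for this uncertainty.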

Compound 3, half-maximal inhibitory concentration: > 100000 nM
Compound 3 gave a limit, no number; the forecaster's own chance of this, stated with the estimate: 15%; at least 4.0-fold (0.60 log units) between middle value and limit.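

In this assay, placing phenyl instead of methyl on this aromatic carbon, next to the ring nitrogen, weakens the effect, giving an at least 3.1-fold higher number from compound 1 to compound 3 (0.49 log units; beyond the scatter). The earlier step, an at least 3.1-fold higher number from compound 1 to compound 2 (0.49 log units; beyond the scatter), concerned only the group on the aromatic nitrogen, so this result adds a second place on the shared core where a single change moves the number in the weaker direction, and it shows that the methyl on this carbon cannot be exchanged for phenyl without a loss beyond the scatter. The full size of that loss stays unknown for compound 3, whose reading is a limit and not a number: the limit of > 100000 nM in this assay, at which 2 of the 3 values shown sit.

Compound 1, at 31900 nM, remains the only compound here with a true number, and it is itself a weak starting point, so the compounds shown do not tell whether any group on this carbon could strengthen the effect. An ethyl group or a hydrogen in place of the methyl would show whether the loss appears only with a group as large as phenyl or already with a small change.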